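Compound 3 to compound 4: a step from the only number

The compounds below may be only part of what the source reports. "The series", "measured", "known", "first", "only" and "open" are said of these compounds alone.

Working notes on the series, read in a functional assay on HT-29 cells (Homo sapiens) for inhibition, read by CCK-8 assay, with a stated time of 24 h; a lower number here means a stronger inhibitor, a higher number a weaker inhibitor. Compound 1 `O=C1Nc2ccccc2/C1=C/c1ccc(-c2cn(-c3cccc(F)c3)nn2)cc1` gives only a limit, > 20000 nM. Compound 2 `O=C1Nc2ccccc2/C1=C/c1ccc(-c2cn(-c3cccc(Cl)c3)nn2)cc1` also gives only a limit, > 20000 nM. For the measured compounds named here, compound 3 `N#Cc1ccccc1-n1cc(-c2ccc(/C=C3\C(=O)Nc4ccccc43)cc2)nn1` gives 14400 nM, the only true number so far; the rest of the evidence ends at the limit of > 20000 nM in this assay, at which 2 of the 3 values shown sit.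

Compound 4 `O=C1Nc2ccccc2/C1=C/c1ccc(-c2cn(-c3ccc(Cl)c(C(F)(F)F)c3)nn2)cc1` keeps the shared core and changes one group: 4-chloro-3-(trifluoromethyl)phenyl in place of 2-cyanophenyl on an aromatic nitrogen. In words, 4-chloro-3-(trifluoromethyl)phenyl stands in place of 2-cyanophenyl on an aromatic nitrogen.

Going by the values given here, two measured steps bear on this change: an at least 1.3-fold lower number from compound 1 to compound 3 (0.14 log units; that floor lies within the scatter) and an at least 1.3-fold lower number from compound 2 to compound 3 (0.14 log units; that floor lies within the scatter). On these data alone, both are read against a limit, so their true size is unknown. Both also end on the 2-cyanophenyl group that compound 4 gives up, so they run opposite to the step in question. The step that the two limits leave unreadable from compound 1 to compound 2 adds nothing on size. Neither compound 1 nor compound 2 carries the entering group, so the guidance is indirect.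

No step beyond the scatter is expected, and any drift should be toward a higher number. The expected step is a 1.3-fold higher number from compound 3 to compound 4 (0.10 log units; within the scatter). For compound 4 the estimated value is 18000 nM, with an expected range from 7000 nM to 40000 nM.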

Compound 4, half-maximal inhibitory concentration: 9670 nM
Compound 4: the middle estimate sits 1.9-fold (0.27 log units) above what was measured; the range from low to high includes it.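

In this assay, the aryl group on this aromatic nitrogen now gives steps beyond the scatter against both halophenyl compounds: an at least 2.0-fold lower number from compound 1 to compound 4 (0.31 log units; beyond the scatter) and an at least 2.0-fold lower number from compound 2 to compound 4 (0.31 log units; beyond the scatter). Against the only earlier true number, the change gives a 1.5-fold lower number from compound 3 to compound 4 (0.17 log units; within the scatter), so compound 3 and compound 4 cannot be told apart, and a measurable value at this position does not depend on the nitrile of the 2-cyanophenyl group. Compound 1 and compound 2 each remain a limit of the assay and not a number, so the true size of the two steps beyond the scatter stays unknown: the limit of > 20000 nM in this assay, at which 2 of the 4 values shown sit.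

On these data alone, it remains open whether the trifluoromethyl, the chloro or only their combination in the 4-chloro-3-(trifluoromethyl)phenyl group accounts for the difference from compound 1 and compound 2, and a phenyl carrying the trifluoromethyl alone would separate these readings. Also open, as far as these compounds go, is how an amine or a carboxylic acid on this phenyl, or a simple alkyl chain in its place on the aromatic nitrogen, would read in this assay.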